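A third fluoro on a series held at its limit

The compounds below may be only part of what the source reports. "The series", "measured", "known", "first", "only" and "open" are said of these compounds alone.

In an ADME assay on HEK293 cells (Homo sapiens) for cytotoxicity, with a stated time of 72 h (on this read-out lower numbers stand for an effect already at smaller amounts and higher numbers for an effect only at larger amounts of compound), compound 1 `C=C[C@@](C)(/C=C/c1ccc(OCc2ccccc2)cc1)CCC=C(C)C` gives > 36600 nM which is a limit and not a number. Compound 2 `C=C[C@@](C)(/C=C/c1ccc(Nc2ccccc2)cc1)CCC=C(C)C` gives > 36600 nM as a limit too. Compound 3 `C=C[C@@](C)(/C=C/c1ccc(Nc2ccc(F)c(F)c2)cc1)CCC=C(C)C` gives > 36600 nM again as a limit, so it has no number of its own. The picture so far is the limit of > 36600 nM in this assay, at which 3 of the 3 values shown sit, and the three compounds cannot be ranked.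

Compound 4 `C=C[C@@](C)(/C=C/c1ccc(Nc2cc(F)c(F)c(F)c2)cc1)CCC=C(C)C` differs from compound 3 by one change: fluoro in place of hydrogen on an aromatic carbon and so 3,4-difluorophenyl becomes 3,4,5-trifluorophenyl. The closest measured change is a step that the two limits leave unreadable from compound 2 to compound 3 while a step that the two limits leave unreadable from compound 1 to compound 2 and a step that the two limits leave unreadable from compound 1 to compound 3 tell no more. With a step that the two limits leave unreadable from compound 2 to compound 3 as the closest guide, no step beyond the scatter is expected in this assay in either direction. The estimated change is a step that the limit leaves unreadable from compound 3 to compound 4 and the assay is expected to report only a limit again. The estimated value for compound 4 is 45000 nM within an expected range from 20000 nM to 100000 nM if a number is reported at all.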

Compound 4, half-maximal effective concentration: > 36600 nM
Compound 4: a limit, no number; the forecaster's own chance of this, stated with the estimate: 85%; the middle value is on the limit's open side.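

Compound 4 also gives only a limit in this assay, so neither the step from compound 3 to compound 4 nor the one from compound 2 to compound 4 can be read, and the picture stays: the limit of > 36600 nM in this assay, at which 4 of the 4 values shown sit.

The compounds shown leave open whether any change among compound 1, compound 2, compound 3 and compound 4 shifts the read-out at all.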